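Methyl for Hydrogen on Two Different Saturated Carbons

A few compounds are considered here, and "the series" means these few. Any claim that something is new, unique, unknown or untested is made for them only; others in the source may bear on it.

The study concerns two cores. Compound 1 `CN1CCN(c2ccc(S(=O)(=O)Oc3cccc(F)c3)cc2)C1=O` and compound 2 `CCN1CCN(c2ccc(S(=O)(=O)Oc3cccc(F)c3)cc2)C1=O` share one; compound 3 `CCCN1CCN(c2ccc(S(=O)(=O)Oc3ccccc3C)cc2)C1=O` and the as yet unmeasured compound 4 `CCCN1CCN(c2ccc(S(=O)(=O)Oc3ccccc3CC)cc2)C1=O` share another, and the difference between the two cores is not broken down here. In a functional assay on M21 cells (Homo sapiens) for antiproliferative activity, read by sulforhodamine B assay, with a stated time of 48 h (a higher number here means a weaker inhibitor, a lower number a stronger inhibitor), compound 1 gives 5800 nM. Compound 2 gives 11000 nM in this assay, a change of methyl in place of hydrogen on a saturated chain carbon bound to an amide-type nitrogen in a ring that produced a 1.9-fold higher number from compound 1 to compound 2 (0.28 log units; within the scatter). For compound 3 the result in this assay is only a limit, > 100000 nM, as the limit of > 100000 nM in this assay, at which 1 of the 3 values shown sits, records.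

Compound 4 carries the same kind of change as compound 2, namely (methyl in place of hydrogen on a saturated chain carbon bound to an aromatic carbon), though here the saturated chain carbon is bound to an aromatic carbon rather than to an amide-type nitrogen in a ring. Since the earlier step of a 1.9-fold higher number from compound 1 to compound 2 (0.28 log units; within the scatter) stayed within the scatter, the expected step is a step that the limit leaves unreadable from compound 3 to compound 4, and because compound 3 already sits at the limit > 100000 nM, compound 4 is expected to do so as well. In this assay compound 4 is thus estimated at 150000 nM, with a range from 50000 nM to 500000 nM.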

Compound 4, half-maximal inhibitory concentration: > 50000 nM
Compound 4 ended at the assay's limit; the forecaster's own chance of this, stated with the estimate: 75%; the middle value does not contradict the limit.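

In this assay compound 3 and compound 4 both stand only at limits, so no step can be read between them, and the change from methyl to ethyl has no size here. The compounds shown leave open whether this change alters the number at all on this core, and how it would compare with the change from compound 1 to compound 2.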